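Thiophen-2-yl at the saturated ring carbon of the core

The source may hold more compounds than are shown below. What is called first, only, known or untested is meant among the compounds shown, and "the series" means these compounds.

Compound 2 `COc1cc(N2C(N)=C(C#N)C(c3cccc([N+](=O)[O-])c3)C3=C2CC(C)(C)CC3=O)cc(OC)c1OC` stands highest of the two numbers in hand: in a functional assay on Ehrlich cells (Mus musculus) for cytotoxicity, tested at 50 ug/mL (on this read-out higher numbers stand for a stronger effect at the one concentration tested and lower numbers for a weaker effect), compound 2 gives 30%. Going by the values given here, its nearest neighbour is compound 1 `COc1cc(N2C(N)=C(C#N)C(c3ccccc3O)C3=C2CC(C)(C)CC3=O)cc(OC)c1OC`, which in this assay gives 2%; the single measured step, a number 28 percentage points higher from compound 1 to compound 2 (beyond the scatter), shows that the aryl group on the saturated ring carbon of the shared core moves the read-out well beyond the scatter.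

Compound 3 `COc1cc(N2C(N)=C(C#N)C(c3cccs3)C3=C2CC(C)(C)CC3=O)cc(OC)c1OC` is the next member. It differs from compound 2 in one place: thiophen-2-yl in place of 3-nitrophenyl on a saturated ring carbon. Among the compounds with values here, no measured step covers a five-membered heteroaryl group at this position, so the only guidance is indirect. The step of a number 28 percentage points higher from compound 1 to compound 2 (beyond the scatter) shows that replacing one six-membered aryl by another already moved the number modestly, and compound 2 carries the group that gave the highest read-out so far. A thiophen-2-yl group is therefore expected to give a smaller number than compound 2, with wide uncertainty; the expected step is a number 18 percentage points lower from compound 2 to compound 3 (beyond the scatter). For compound 3 the estimate in this assay is 12%, within a range of 0% to 35%.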

Compound 3, a percentage reported as activity, at one concentration (the size of the read-out at that concentration, not a potency): 15%
Compound 3: middle estimate off by 3 percentage points, on the low side, within the range that was stated.
By their numbers in this assay, from the lowest: compound 1; then compound 3; then compound 2.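

In this assay thiophen-2-yl gives a number in the middle of the three: a number 15 percentage points lower from compound 2 to compound 3 (beyond the scatter) and a number 13 percentage points higher from compound 1 to compound 3 (beyond the scatter) place compound 3 apart from both six-membered aryl compounds. This position therefore accepts a five-membered aromatic ring with a sulfur atom and keeps a read-out beyond the scatter above that of compound 1, so a nitro group is not needed for a number above that of compound 1 within this set. The three compounds give an order at one concentration only, and no supporting measurement bears on what lies behind that order.

Still open, going by these compounds, is how an unsubstituted phenyl, a furan ring or a phenyl ring bearing an amine or a carboxylic acid would read at this saturated ring carbon, and a plain phenyl in particular would help separate the part played by the hydroxyl group of compound 1 from that of the nitro group of compound 2. Also open, on these data alone, is whether the order among compound 1, compound 3 and compound 2 would hold at other concentrations or with another group in place of the 3,4,5-trimethoxyphenyl group.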